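Working notes: carbonyl-to-sulfonyl exchange on the aryl nitrogen

This account rests on a few compounds, and the source may have more. Where it says the series, first, only, none or still open, it means among the compounds named here.

Measured so far:
Compound 1 `COc1cccc(C(=O)Nc2cccc(/C=C/C(=O)c3nc4ccccc4[nH]3)c2)c1` — 17800 nM
Compound 2 `Cc1cc(C)cc(C(=O)Nc2cccc(/C=C/C(=O)c3nc4ccccc4[nH]3)c2)c1` — 24600 nM

Within the data shown here, in a functional assay on MCF7 cells (Homo sapiens) for antiproliferative activity, read by MTT assay, with a stated time of 48 h (on this read-out higher numbers stand for weaker inhibition and lower numbers for stronger inhibition), compound 2 gives 24600 nM, and compound 1 gives 17800 nM; the one measured step, a 1.4-fold higher number from compound 1 to compound 2 (0.14 log units; within the scatter), is within the scatter, so compound 2 stands alongside compound 1 rather than apart from it. Compound 3 `Cc1ccc(S(=O)(=O)Nc2cccc(/C=C/C(=O)c3nc4ccccc4[nH]3)c2)cc1` differs from compound 2 in one place: (4-methylphenyl)sulfonyl in place of (3,5-dimethylphenyl)carbonyl on a nitrogen on an aromatic ring. Among the measured compounds shown here, the step of a 1.4-fold higher number from compound 1 to compound 2 (0.14 log units; within the scatter) concerns a different change, the aryl group attached to the carbonyl carbon, and no measured pair spans the exchange of the carbonyl for a sulfonyl on the ring nitrogen. Nothing in the measured numbers indicates a direction for this exchange, so no step beyond the scatter is expected, and the estimated step is a 1.0-fold higher number from compound 2 to compound 3 (0.01 log units; within the scatter). From the compounds shown here alone, compound 3 is therefore expected to give 25000 nM in this assay, within a range of 8000 nM to 80000 nM, the width reflecting that the change is untested.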

Compound 3, half-maximal inhibitory concentration: 3220 nM
The estimate for compound 3 lay 7.8-fold (0.89 log units) above the measured number; the measured number lies below the stated range.
By their numbers in this assay, from the lowest: compound 3; then compounds 1 and 2 (each within the scatter of the next).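

On this assay, the position on the aryl nitrogen responds to the change of group: replacing either carbonyl-linked aryl group with (4-methylphenyl)sulfonyl gives a 7.6-fold lower number from compound 2 to compound 3 (0.88 log units; beyond the scatter) and a 5.5-fold lower number from compound 1 to compound 3 (0.74 log units; beyond the scatter). The exchange between the two aryl groups on the carbonyl, by contrast, gives only a 1.4-fold higher number from compound 1 to compound 2 (0.14 log units; within the scatter), so in these compounds the sulfonyl compound stands apart from the two carbonyl compounds, which stay together. No measurement shown explains this difference.

The entering group differs from the leaving groups in both the linking unit and the aryl pattern, so the contribution of the sulfonyl cannot be separated from that of the 4-methylphenyl. Also open, from the compounds shown here alone, is whether the result holds with (3,5-dimethylphenyl)sulfonyl or with a small methylsulfonyl on the same nitrogen.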